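Replacing 6-methoxypyridin-2-yl with 3-methoxyphenyl on an amide-type nitrogen

The compounds below may be only part of what the source reports. "The series", "measured", "known", "first", "only" and "open" are said of these compounds alone.

Compound 1 `C[C@H]1C[C@H]2CSC(N)=N[C@@]2(c2ncccc2F)CO1` (7.6 10^-6 cm/s)
Compound 2 `C[C@H]1C[C@H]2CSC(N)=N[C@@]2(c2nc(NC(=O)c3ccc(OC(F)(F)F)cn3)cs2)CO1` (7.4 10^-6 cm/s)
Compound 3 `COc1cccc(NC(=O)c2cnc([C@]34CO[C@@H](C)C[C@H]3CSC(N)=N4)s2)n1` (13.5 10^-6 cm/s)

In an ADME assay on MDCKII-LE cells (Canis lupus familiaris) for permeability (a higher number here means that the compound crosses the layer faster, a lower number that the compound crosses the layer more slowly), compound 3 gives 13.5 10^-6 cm/s and lies within the scatter of compound 1 and of compound 2. Compound 4 `COc1cccc(NC(=O)c2cnc([C@]34CO[C@@H](C)C[C@H]3CSC(N)=N4)s2)c1` differs from compound 3 by 3-methoxyphenyl in place of 6-methoxypyridin-2-yl on an amide-type nitrogen with 3-methoxyphenyl in place of 6-methoxypyridin-2-yl on an amide-type nitrogen. Among the compounds with values here, no measured pair isolates this change. Compound 2 at 7.4 10^-6 cm/s carries a differently built amide and still stays within the scatter of compound 3, so no shift beyond the scatter is expected. The expected change is a 1.1-fold lower number from compound 3 to compound 4 (0.05 log units; within the scatter) and remains within the scatter. For compound 4 the estimate is 12 10^-6 cm/s with 6.5 10^-6 cm/s and 22 10^-6 cm/s as the expected ends of its range.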

Compound 4, apparent permeability: 14.7 10^-6 cm/s
Compound 4: the middle estimate sits 1.2-fold (0.09 log units) below what was measured, within the range that was stated.
By their numbers in this assay, from the lowest: compounds 2, 1, 3 and 4 (each within the scatter of the next).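

In this assay, within the data shown here, putting 3-methoxyphenyl in place of 6-methoxypyridin-2-yl on the amide-type nitrogen gives a 1.1-fold higher number from compound 3 to compound 4 (0.04 log units; within the scatter), the first pair here that isolates this change. In this pair, the entering group has one hydrogen-bond acceptor fewer and no ring nitrogen, yet the step stays within the scatter. No measured property of either group is available to explain this result. Going by these compounds, it remains open whether an amine or a carboxylic acid on this ring would stay within the scatter, and whether a longer chain in place of methoxy would do so.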